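A few compounds are considered here, and "the series" means these few. Any claim that something is new, unique, unknown or untested is made for them only; others in the source may bear on it.

Two compounds have numbers in an assay on RPMI-8866 cells for inhibition of integrin alpha-4/beta-1 (Homo sapiens); a higher number here means a weaker inhibitor, a lower number a stronger inhibitor. Compound 1, `CC(C)[C@H](CC(=O)O)NC(=O)[C@@H]1CCCN1S(=O)(=O)c1cc(Cl)cc(Cl)c1`, gives 362 nM in this assay. Compound 2, `O=C(O)C[C@@H](NC(=O)[C@@H]1CCN1S(=O)(=O)c1cc(Cl)cc(Cl)c1)c1ccc(F)cc1`, gives 3.2 nM in this assay, the lowest of the two numbers; the gap to compound 1 lies well beyond the scatter, but the two compounds differ in more than one place, so only the two values themselves can be set side by side. Compound 3, `O=C(O)C[C@@H](NC(=O)[C@@H]1CCN1S(=O)(=O)c1cc(Cl)cc(Cl)c1)c1ccc(OC2CCCC2)cc1`, has not yet been measured. It differs from compound 2 in a single place: cyclopentyloxy in place of fluoro on an aromatic carbon, on an aromatic carbon of a six-membered aromatic ring of carbon only, para to a large group. Among the measured compounds shown here, no pair of measured compounds shows this change, so there is no measured step to lean on. The estimated step from compound 2 to compound 3 is a 1.3-fold lower number from compound 2 to compound 3 (0.11 log units; within the scatter), a shift expected to stay within the usual scatter, with no clear direction. For compound 3 the estimated value in this assay is 2.5 nM, with a range from 0.4 nM to 15 nM.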

Compound 3, half-maximal inhibitory concentration: 0.5 nM
For compound 3 the middle estimate is 5.0-fold (0.70 log units) above the measured one, within the range that was stated.
By their numbers in this assay, from the lowest: compound 3; then compound 2; then compound 1.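

In this assay, cyclopentyloxy in place of fluoro on an aromatic carbon, para to a large group, gives a 6.4-fold lower number from compound 2 to compound 3 (0.81 log units; beyond the scatter), a step beyond the scatter. Among the compounds shown here, this is the first single-place comparison, as compounds 1 and 2 differ in more than one place and could only be set side by side. It shows that at this position, a group of 6 heavy atoms carrying a five-membered non-aromatic ring can replace the 1 heavy atom of fluoro, with the number falling rather than rising. Nothing available here accounts for why the number moves in this direction.

With only one replacement shown at this position, it remains open whether the lower number goes with the ether oxygen or with the five-membered ring, a question that a methoxy group and a cyclopentyl group joined directly to the aromatic carbon could help to separate. On these data alone, how this position responds to an amine or a carboxylic acid also remains open.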